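A Methoxy Step Read Across Three Cytotoxicity Limits

The source may hold more compounds than are shown below. What is called first, only, known or untested is meant among the compounds shown, and "the series" means these compounds.

Compound 1 `COc1ccc(CNc2ncnc3c2ncn3C2CCCCO2)c(OC)c1` and compound 2 `COc1ccc(CNc2ncnc3c2ncn3C2CCCCO2)c(OC)c1OC` share one core, while compound 3 `COc1ccc(CNc2ncnc3c2ncn3C2CCCO2)cc1` and compound 4 `COc1ccc(CNc2ncnc3c2ncn3C2CCCO2)cc1OC` share another; the difference between the two cores is not broken down here. In an ADME assay on MCF7 cells (Homo sapiens) for cytotoxicity, with a stated time of 72 h (on this read-out higher numbers stand for weaker inhibition and lower numbers for stronger inhibition), compound 1 gives > 25000 nM, which is a limit of the assay and not a number. Compound 2 gives > 37500 nM in this assay, again a limit. The step from compound 1 to compound 2 is a step that the two limits leave unreadable from compound 1 to compound 2, the change being (methoxy in place of hydrogen on an aromatic carbon). Compound 3 gives > 100000 nM in this assay, also a limit. Compound 4 carries the same kind of change on its own core, (methoxy in place of hydrogen on an aromatic carbon); here the entering group sits ortho to a methoxy group, whereas in compound 2 it sits ortho to two methoxy groups. Among the compounds with values here, all three results so far stand at limits, the limit of > 100000 nM in this assay, at which 1 of the 3 values shown sits, the limit of > 25000 nM in this assay, at which 1 of the 3 values shown sits (the limit of > 37500 nM in this assay, at which 1 of the 3 values shown sits), so no numeric step is readable from them. The step from compound 3 to compound 4 is expected to be a number no higher from compound 3 to compound 4 (the limit leaves the size open). This expectation rests on compound 3, whose result > 100000 nM is a limit. Compound 4 is estimated at 100000 nM, with a range from 30000 nM to 300000 nM, and most likely reported only as a limit.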

Compound 4, half-maximal inhibitory concentration: > 100000 nM
Compound 4 was reported as a limit (the forecaster's own chance of this, stated with the estimate: 90%); the middle value lies on the limit itself.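

In this assay compound 4 gives > 100000 nM, which is a limit of the assay and not a number. Compound 3 also stands at a limit, so no step can be read between compound 3 and compound 4. The compounds shown leave open whether methoxy in place of hydrogen on an aromatic carbon alters cytotoxicity in this assay on either core.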